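Methyl in Place of Hydroxy Hydrogen on a Lactone Core

This account rests on a few compounds, and the source may have more. Where it says the series, first, only, none or still open, it means among the compounds named here.

Measured so far in a functional assay on MCF7 cells (Homo sapiens) for inhibition, read by sulforhodamine B assay; on this read-out higher numbers stand for lower toxicity in this test and lower numbers for higher toxicity in this test:
Compound 1 `C=C1CC[C@H]2C(C)(C)CCC[C@]2(C)[C@H]1C/C=C1/CC(O)OC1=O` gives 21900 nM.
Compound 2 `C=C1CC[C@H]2C(C)(C)CCC[C@]2(C)[C@H]1CCC1=CC(O)OC1=O` gives 40700 nM.

Compound 1 holds the lowest of the two numbers recorded in this assay, but its nearest neighbour, compound 2, stands at a distance that lies within the scatter of repeated measurements, so the two cannot be told apart on this read-out. The two compounds differ at more than one place, so no single structural step can be read from them.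

Compound 3 `C=C1CC[C@H]2C(C)(C)CCC[C@]2(C)[C@H]1C/C=C1/CC(OC)OC1=O` has not yet been measured. It differs from compound 1 in one place: methyl in place of hydrogen on an oxygen on a saturated carbon, read one bond further out as hydroxy to methoxy. Within the data shown here, no measured pair in this set isolates a change of this kind, so there is no direct precedent for its effect in this assay. A small step, or none beyond the scatter, is expected for a 1.1-fold lower number from compound 1 to compound 3 (0.04 log units; within the scatter). Compound 3 is therefore estimated to give 20000 nM in this assay, with a range from 7000 nM to 60000 nM.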

Compound 3, concentration lethal to 50% of the cells: 31600 nM
Estimate against measurement, compound 3: 1.6-fold (0.20 log units) below, within the range that was stated.
By their numbers in this assay, from the lowest: compounds 1, 3 and 2 (each within the scatter of the next).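

Hydroxy to methoxy on this saturated carbon gives the first comparison in this set that isolates a single place, and in this assay it reads as a 1.4-fold higher number from compound 1 to compound 3 (0.16 log units; within the scatter) and so leaves the two compounds indistinguishable. In this one pair, then, the hydrogen on this oxygen can give way to methyl without a step beyond the scatter, which the earlier pair of compounds, differing at more than one place, could not show. No independent evidence accompanies this result to account for it or to tie it to any property of either group.

The compounds shown leave open whether a longer chain on this oxygen, such as ethyl or butyl, or an amine or a carboxylic acid in place of the hydroxy, would give a step beyond the scatter on this read-out. They also leave open whether the same exchange of hydroxy for methoxy would read alike on compound 2, and whether this position matters at all for toxicity in this test.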